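Chloro to Methoxy: Expectations for an Unmeasured Compound

The source may report more compounds than this note shows. Statements on the series, on what has been measured and on what is new or still open speak of the compounds shown alone.

Compound 1, compound 2 and compound 3 share a core and have been measured in an ADME assay on Raji cells (Homo sapiens) for cytotoxicity, with a stated time of 72 h; a higher number here means that more compound is needed for the effect, a lower number that less compound is needed. Compound 1 `Cc1cc(NC(=O)Nc2ccc(Cl)c(Cl)c2)c2ccccc2n1` gives 10000 nM in this assay. Compound 2 `COc1ccc(NC(=O)Nc2cc(C)nc3ccccc23)cc1Cl` gives > 25000 nM, a limit of the assay rather than a number. Compound 3 `Cc1cc(NC(=O)Nc2ccc(Cl)cc2)c2ccccc2n1` likewise gives > 25000 nM, again a limit of the assay. The steps are an at least 2.5-fold higher number from compound 1 to compound 2 (0.39 log units; beyond the scatter) and an at least 2.5-fold higher number from compound 1 to compound 3 (0.39 log units; beyond the scatter); both rest on (the limit of > 25000 nM in this assay, at which 2 of the 3 values shown sit).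

Compound 4 `COc1ccc(NC(=O)Nc2cc(C)nc3ccccc23)cc1` has not yet been measured. It differs from compound 3 by methoxy in place of chloro on an aromatic carbon. The same kind of change separates compound 1 from compound 2, namely (methoxy in place of chloro on an aromatic carbon), though there the place is also ortho to a chloro group (1 heavy atom), which is absent around the place in compound 4. The two cores differ by hydrogen in place of chloro on an aromatic carbon.

The step expected here is a step that the limit leaves unreadable from compound 3 to compound 4. This expectation rests on compound 3, which already gives > 25000 nM, a limit of the assay. Compound 4 is therefore estimated at 40000 nM, with a range from 20000 nM to 120000 nM.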

Compound 4, half-maximal effective concentration: > 25000 nM
Compound 4 was reported as a limit (the forecaster's own chance of this, stated with the estimate: 85%); the middle value does not contradict the limit.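

In this assay compound 4 gives > 25000 nM, a limit of the assay and not a number. No new step can be read from compound 3 or compound 2 to compound 4: the limit of > 25000 nM in this assay, at which 3 of the 4 values shown sit. The compounds shown leave open what actual numbers compound 2, compound 3 and compound 4 would give, and whether methoxy in place of chloro changes anything here.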